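Same atoms rearranged: compound 1 to compound 3

This account rests on a few compounds, and the source may have more. Where it says the series, first, only, none or still open, it means among the compounds named here.

Compound 1 (`O=C1O/C(=C\Cn2cnc3c(F)nc(F)c(Cl)c32)C(OCc2ccccc2)=C1OCc1ccccc1`) gives > 100000 nM in a functional assay on HeLa cells (Homo sapiens) for antiproliferative activity, read by MTT assay, with a stated time of 72 h (a lower number here means a stronger inhibitor, a higher number a weaker inhibitor), as a limit of the assay and not a number. Going by the values given here, compound 2 (`O=C1O/C(=C\Cn2cnc3ccn(C/C=C4\OC(=O)C(OCc5ccccc5)=C4OCc4ccccc4)c3c2=O)C(OCc2ccccc2)=C1OCc1ccccc1`) gives 5600 nM in this assay and holds the only numeric value so far. Compound 3 (`O=C1O/C(=C\Cn2cnc3c(Cl)c(F)nc(F)c32)C(OCc2ccccc2)=C1OCc1ccccc1`) carries the same atoms as compound 1 joined differently (a group of 12 heavy atoms (6 carbon, 3 nitrogen, 2 fluorine, 1 chlorine; one five-membered aromatic ring with 2 hetero atoms, one six-membered aromatic ring with 1 hetero atom) in place of a group of 12 heavy atoms (6 carbon, 3 nitrogen, 2 fluorine, 1 chlorine; one five-membered aromatic ring with 2 hetero atoms, one six-membered aromatic ring with 1 hetero atom), on a saturated chain carbon bound to a double-bonded chain carbon). Among the compounds with values here, no measured step covers this change. A modest step toward a lower number is expected in this assay and no more. The expected size is an at least 1.2-fold lower number from compound 1 to compound 3 (0.09 log units; that floor lies within the scatter) on this estimate. Compound 3 is estimated at 80000 nM with an expected range from 15000 nM to 200000 nM and may again read as a limit.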

Compound 3, half-maximal inhibitory concentration: > 100000 nM
Compound 3 was reported as a limit (the forecaster's own chance of this, stated with the estimate: 60%); middle value at least 1.2-fold (0.09 log units) away from the limit.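

No step from compound 1 to compound 3 can be read, since both values are limits and not numbers: the limit of > 100000 nM in this assay, at which 2 of the 3 values shown sit.

As far as these compounds go, whether joining the atoms of this group differently changes activity at all stays open.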